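Ester in place of amide on a nucleoside sulfonate scaffold

The source may hold more compounds than are shown below. What is called first, only, known or untested is meant among the compounds shown, and "the series" means these compounds.

From the compounds shown here alone, the study compares three measured compounds and one still open. Compound 1 `Cc1cn([C@@H]2O[C@H](CO[Si](C)(C)C(C)(C)C)[C@@]3(OS(=O)(=O)C=C3NCC(N)=O)[C@H]2O[Si](C)(C)C(C)(C)C)c(=O)n(C)c1=O` and compound 2 `COC(=O)CNC1=CS(=O)(=O)O[C@@]12[C@@H](CO[Si](C)(C)C(C)(C)C)O[C@@H](n1cc(C)c(=O)n(C)c1=O)[C@@H]2O[Si](C)(C)C(C)(C)C` share a core and differ only in the group on the carbonyl carbon, (methoxy in place of amino on a carbonyl carbon). In a functional assay on HEL cells (Homo sapiens) (on this read-out lower numbers stand for higher toxicity in this test and higher numbers for lower toxicity in this test), compound 1 gives 13500 nM, while compound 2 gives 160000 nM, so the step is a 12-fold higher number from compound 1 to compound 2 (1.07 log units; beyond the scatter). Compound 3 `Cc1cn([C@@H]2O[C@H](CO[Si](C)(C)C(C)(C)C)[C@@]3(OS(=O)(=O)C=C3NCCC(N)=O)[C@H]2O[Si](C)(C)C(C)(C)C)c(=O)n(C)c1=O` carries a longer chain, differing from compound 1 by carbamoylmethyl in place of carbamoyl on a saturated chain carbon bound to an amine nitrogen, and in this assay compound 3 gives 14800 nM, a step of a 1.1-fold higher number from compound 1 to compound 3 (0.04 log units; within the scatter). Between compound 2 and compound 3 the step is an 11-fold lower number from compound 2 to compound 3 (1.03 log units; beyond the scatter).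

Compound 4 `COC(=O)CCNC1=CS(=O)(=O)O[C@@]12[C@@H](CO[Si](C)(C)C(C)(C)C)O[C@@H](n1cc(C)c(=O)n(C)c1=O)[C@@H]2O[Si](C)(C)C(C)(C)C` has not yet been measured. It differs from compound 3 by methoxy in place of amino on a carbonyl carbon, the same change that turned compound 1 into compound 2, at the same kind of place. Because the first occurrence gave a 12-fold higher number from compound 1 to compound 2 (1.07 log units; beyond the scatter), a step of similar size is expected, an 11-fold higher number from compound 3 to compound 4 (1.03 log units; beyond the scatter), from compound 3 to compound 4 in this assay. On that basis compound 4 is estimated at 160000 nM, with a likely range from 60000 nM to 400000 nM.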

Compound 4, half-maximal cytotoxic concentration: 94000 nM
Beside the measured number, compound 4's estimate is 1.7-fold (0.23 log units) above it, within the range that was stated.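

In this assay the change of amino to methoxy on a carbonyl carbon again gives a higher number, a 6.4-fold higher number from compound 3 to compound 4 (0.80 log units; beyond the scatter), and the two occurrences agree in direction and, within the scatter, in size: the same change on two cores in this assay, a 12-fold higher number (1.07 log units; beyond the scatter) from compound 1 to compound 2 and a 6.4-fold higher number (0.80 log units; beyond the scatter) from compound 3 to compound 4, 1.9-fold (0.27 log units) apart, within the scatter of two such steps. The ester pair also sits within the scatter, a 1.7-fold lower number from compound 2 to compound 4 (0.23 log units; within the scatter), while the step across both the group and the chain, a 7.0-fold higher number from compound 1 to compound 4 (0.84 log units; beyond the scatter), is beyond it. This shows that the change carried over between two cores that differ only in the chain on the amine nitrogen, but with just two pairs it does not show that it would carry to a core altered anywhere else, nor does it explain why the number moves.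

The compounds shown leave open whether a carboxylic acid or an ethyl ester in place of the methyl ester would follow the same course. They also leave open whether a longer chain on the amine nitrogen would preserve the step.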